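This account rests on a few compounds, and the source may have more. Where it says the series, first, only, none or still open, it means among the compounds named here.

Working notes on the series in an ADME assay on MT4 cells (Homo sapiens) for cytotoxicity, read by MTT assay, with a stated time of 96 h; a higher number here means that more compound is tolerated, a lower number that less compound is tolerated. Compound 1 `COc1ccc(-c2nc3cc(C(C)=O)ccc3[nH]2)c(OC)c1` gives 50000 nM, compound 2 `CC(=O)c1ccc2c(c1)nc(-c1ccc(Cl)cc1)n2C1CCCCC1` gives 58000 nM and compound 3 `COc1ccc(-c2nc3cc(C(C)=O)ccc3n2C2CCCCC2)cc1` gives 27000 nM. Compound 3 lies within the scatter of compound 1 and beyond the scatter of compound 2.

Compound 4 `COc1ccc(-c2nc3cc(C(C)=O)ccc3n2C2CCCCC2)c(OC)c1` departs from compound 3 by one change: methoxy in place of hydrogen on an aromatic carbon. This is methoxy in place of hydrogen on an aromatic carbon, ortho to a large group and meta to a methoxy group.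

Among the measured compounds shown here, no measured step shows this exact change. The nearest is a 2.1-fold lower number from compound 2 to compound 3 (0.33 log units; beyond the scatter), a modest step with methoxy in place of chloro on an aromatic carbon, so adding a methoxy group may lower the number slightly, if at all. Against that, compound 1 carries both methoxy groups of compound 4 but differs elsewhere, and compound 1 gives 50000 nM. Taken together, these two observations point to no clear direction, and no shift beyond the scatter is expected in this assay. The estimated change is a 1.1-fold higher number from compound 3 to compound 4 (0.05 log units; within the scatter). The expected value for compound 4 is 30000 nM, with an estimated range of 15000 nM to 60000 nM.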

Compound 4, half-maximal cytotoxic concentration: 21000 nM
Compound 4: the middle estimate sits 1.4-fold (0.15 log units) above what was measured; low and high end bracket the measured number.
By their numbers in this assay, from the lowest: compounds 4, 3, 1 and 2 (each within the scatter of the next, the first and the last beyond it).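

Among the compounds shown here, the first direct reading of methoxy in place of hydrogen on this aromatic carbon, ortho to a large group and meta to a methoxy group, comes from this assay: a 1.3-fold lower number from compound 3 to compound 4 (0.11 log units; within the scatter), so at this position the added methoxy leaves the number within the scatter of compound 3, and the step gives no basis for assigning a direction to this change. The series also gains its first reading of cyclohexyl in place of hydrogen on an aromatic nitrogen, a 2.4-fold lower number from compound 1 to compound 4 (0.38 log units; beyond the scatter), a modest step that lies beyond the scatter and is the larger of the two new steps. Nothing available here bears on the cause of either step.

Going by these compounds, the cyclohexyl step rests on this single pair with the two methoxy groups in place, so whether it holds with the chloro group of compound 2, or whether a methyl group or a longer chain on the same nitrogen gives a similar step, stays open. Also open, on these data alone, is whether an amine or a carboxylic acid on the same aromatic carbon would move the number beyond the scatter.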